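This account rests on a few compounds, and the source may have more. Where it says the series, first, only, none or still open, it means among the compounds named here.

Measured in a functional assay on MCF7 cells (Homo sapiens) for inhibition, read by sulforhodamine B assay, with a stated time of 48 h, tested at 50 uM (a higher number here means more inhibition of growth at the concentration tested, a lower number less inhibition of growth), and sharing one core, compound 1 (`COc1ccc([C@@H]2C/C(=N/OCc3cn(-c4ccc(O)cc4)nn3)c3cc(CC=C(C)C)c(OC)cc3O2)cc1`) gives 63% of inhibition, compound 2 (`COc1ccc([C@@H]2C/C(=N/OCc3cn(-c4ccc(Cl)cc4C)nn3)c3cc(CC=C(C)C)c(OC)cc3O2)cc1`) gives 37% of inhibition and compound 3 (`COc1ccc([C@@H]2C/C(=N/OCc3cn(-c4cc(OC)c(OC)c(OC)c4)nn3)c3cc(CC=C(C)C)c(OC)cc3O2)cc1`) gives 45% of inhibition. Compound 3 thus has one close neighbour (a number 8 percentage points higher from compound 2 to compound 3 (within the scatter)) and one clear gap (a number 18 percentage points lower from compound 1 to compound 3 (beyond the scatter)) among the three. Compound 4 (`COc1ccc([C@@H]2C/C(=N/OCc3cn(-c4ccc(NC(C)=O)cc4)nn3)c3cc(CC=C(C)C)c(OC)cc3O2)cc1`) carries 4-acetamidophenyl in place of 3,4,5-trimethoxyphenyl on an aromatic nitrogen. The steps measured at that nitrogen are modest where they leave the 4-hydroxyphenyl group, and the second such replacement (a number 26 percentage points lower from compound 1 to compound 2 (beyond the scatter)) points the same way as the first, so among these three only compound 1 stands apart. Among the compounds with values here, no measured compound carries 4-acetamidophenyl, so the data offer no direct step for it. No change beyond the scatter is therefore expected, and the estimated step (a number 5 percentage points higher from compound 3 to compound 4 (within the scatter)) leans only slightly upward. Compound 4 is estimated at 50% (expected range 34% to 66%).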

Compound 4, percent growth inhibition at one concentration: 0%
Beside the measured number, compound 4's estimate is 50 percentage points above it, and the stated range ends above it.
By their numbers in this assay, from the lowest: compound 4; then compounds 2 and 3 (each within the scatter of the next); then compound 1.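

In this assay, the earlier replacements on the aromatic nitrogen gave only modest steps, but 4-acetamidophenyl brings large ones (a number 45 percentage points lower from compound 3 to compound 4 (beyond the scatter)) and (a number 37 percentage points lower from compound 2 to compound 4 (beyond the scatter)), so this position can lose all measured inhibition, with compound 4 at 0%. The widest step comes from changing only the group on the aromatic carbon (a number 63 percentage points lower from compound 1 to compound 4 (beyond the scatter)), which shows that the outcome turns on the group carried by the phenyl ring and not on the presence of that ring alone. The data offer no explanation for this loss.

The compounds shown do not tell whether a free amine or a carboxylic acid in place of the acetamido group would restore inhibition. They also leave open whether a single methoxy group there would behave like the hydroxy group of compound 1 or like the acetamido group of compound 4.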